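Swapping the benzyl substituent on the pyrazole carboxamide side chain

This account rests on a few compounds, and the source may have more. Where it says the series, first, only, none or still open, it means among the compounds named here.

Compound 3, `Cc1ccccc1CNC(=O)c1nn(-c2ccc(F)cc2)c(OC[C@@H](O)C[C@@H](O)CC(=O)O)c1C(C)C`, is the middle of three compounds on the numbers shown: in an assay on microsomes from liver for inhibition of 3-hydroxy-3-methylglutaryl-coenzyme A reductase (Rattus norvegicus) (on this read-out higher numbers stand for weaker inhibition and lower numbers for stronger inhibition), compound 3 gives 17 nM. The strongest inhibition belongs to compound 1, `CC(C)c1c(C(=O)NCc2cccc(F)c2F)nn(-c2ccc(F)cc2)c1OC[C@@H](O)C[C@@H](O)CC(=O)O`, which in this assay gives 2 nM; the weakest to compound 2, `Cc1ccc(CN(C)C(=O)c2nn(-c3ccc(F)cc3)c(OC[C@@H](O)C[C@@H](O)CC(=O)O)c2C(C)C)cc1`, which gives 37 nM. Compound 4 is `CC(C)c1c(C(=O)NCc2cccc(Cl)c2)nn(-c2ccc(F)cc2)c1OC[C@@H](O)C[C@@H](O)CC(=O)O`. It differs from compound 3 in one place: 3-chlorophenyl in place of 2-methylphenyl on a saturated chain carbon bound to an amide-type nitrogen. Going by the values given here, no measured step makes this exact exchange. The steps that touch the same part of the molecule are an 8.5-fold higher number from compound 1 to compound 3 (0.93 log units; beyond the scatter) and a 2.2-fold lower number from compound 2 to compound 3 (0.34 log units; beyond the scatter), both beyond the scatter, so the group carried on this carbon clearly moves the read-out, and the compound with halogen on that ring, compound 1, stands lowest at 2 nM. A step of a 2.1-fold lower number from compound 3 to compound 4 (0.33 log units; beyond the scatter) toward stronger inhibition is therefore expected, though the halogen pattern of compound 4 is not that of compound 1. Compound 4 is estimated at 8 nM, within 2.5 nM to 25 nM.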

Compound 4, half-maximal inhibitory concentration: 5.4 nM
Compound 4: the middle estimate sits 1.5-fold (0.17 log units) above what was measured; measured number inside the range.
By their numbers in this assay, from the lowest: compound 1; then compound 4; then compound 3; then compound 2.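

On the saturated chain carbon bound to an amide-type nitrogen, 3-chlorophenyl also gives stronger inhibition than 2-methylphenyl: in this assay the exchange brings a 3.1-fold lower number from compound 3 to compound 4 (0.50 log units; beyond the scatter), so a halogen on this ring no longer stands with compound 1 alone. Even so, the halogen pattern matters, since 3-chlorophenyl in place of 2,3-difluorophenyl gives a 2.7-fold higher number from compound 1 to compound 4 (0.43 log units; beyond the scatter). The replacement of methyl(4-methylbenzyl)amino by (3-chlorobenzyl)amino on the carbonyl carbon gives a 6.9-fold lower number from compound 2 to compound 4 (0.84 log units; beyond the scatter), a larger step than the exchange from 2-methylphenyl.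

Nothing in the information available bears on why these exchanges move the read-out. As far as these compounds go, it remains open whether a 3-bromobenzyl or 3-methoxybenzyl group would match 3-chlorobenzyl, and how a methyl group on the amide-type nitrogen would act alongside 3-chlorobenzyl.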